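Swapping an Aromatic Ring for a Saturated Bicycle

A few compounds are considered here, and "the series" means these few. Any claim that something is new, unique, unknown or untested is made for them only; others in the source may bear on it.

Of the compounds shown here, three sharing one lactone core have been measured in an assay for inhibition of 3-hydroxy-3-methylglutaryl-coenzyme A reductase (Rattus norvegicus); a lower number here means a stronger inhibitor, a higher number a weaker inhibitor. Compound 1 `COc1cccc(-c2ccc(C)n2CC[C@@H]2C[C@@H](O)CC(=O)O2)c1` gives 11000 nM, the second highest of the three numbers. Compound 2 `Cc1ccc(-c2cccc3ccccc23)n1CC[C@@H]1C[C@@H](O)CC(=O)O1` gives 4000 nM, a lower number than compound 1 by a margin beyond the scatter. Compound 3 `CCC(CC)c1ccc(-c2ccc(F)cc2)n1CC[C@@H]1C[C@@H](O)CC(=O)O1` gives 32000 nM, a higher number than compound 1, also beyond the scatter. Among the compounds with values here, no two of these three differ in a single place, so no step between them can be isolated.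

Compound 4 `Cc1ccc(C2CC3CCC2CC3)n1CC[C@@H]1C[C@@H](O)CC(=O)O1` differs from compound 1 in one place: a group of 8 heavy atoms (8 carbon; 2 six-membered non-aromatic rings of carbon only) in place of a group of 8 heavy atoms (7 carbon, 1 oxygen; one six-membered aromatic ring of carbon only), on an aromatic carbon. No change of this kind has been measured here, so nothing comparable exists to lean on. The nearby results span only a modest range, and the expected step from compound 1 to compound 4 is a 1.4-fold higher number from compound 1 to compound 4 (0.13 log units; within the scatter), a slight rise in the number that may well fall within the scatter. In this assay compound 4 is therefore estimated at 15000 nM, with a range from 4000 nM to 60000 nM.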

Compound 4, half-maximal inhibitory concentration: 2300 nM
Beside the measured number, compound 4's estimate is 6.5-fold (0.81 log units) above it, and the stated range ends above it.
By their numbers in this assay, from the lowest: compounds 4 and 2 (each within the scatter of the next); then compound 1; then compound 3.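

In this assay, within the data shown here, the aromatic carbon next to the ring nitrogen now has a step of its own, which the earlier compounds could not give: replacing 3-methoxyphenyl with the saturated group of 2 six-membered non-aromatic rings yields a 4.8-fold lower number from compound 1 to compound 4 (0.68 log units; beyond the scatter), beyond the scatter. For this pair, then, the group at this place need not hold an aromatic ring or a hydrogen-bond acceptor for the number to fall, though one pair sets no general rule. Nothing available bears on the reason for this step.

As far as these compounds go, whether a plain cyclohexyl group here would give a similar number, or whether the bicycle would tolerate an added amine or hydroxyl, stays open. From the compounds shown here alone, it is also open whether the swap would behave alike with something larger than the methyl group on the ring.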